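The source may hold more compounds than are shown below. What is called first, only, known or untested is meant among the compounds shown, and "the series" means these compounds.

In a functional assay on NCI-H520 cells (Homo sapiens) for cytotoxicity (on this read-out higher numbers stand for weaker inhibition of growth and lower numbers for stronger inhibition of growth), compound 1 `COc1ccc(C2=C(c3ccc(SC)cc3)CC3CCCN3C2=O)cc1Br` gives 700 nM and compound 2 `CSc1ccc(C2=C(c3ccc(F)c(F)c3)C(=O)N3CCCC3C2)cc1` gives 200 nM, the lower of the two numbers. Compound 3 `CSc1ccc(C2=C(c3ccc(C)c(C)c3)C(=O)N3CCCC3C2)cc1` differs from compound 2 in one place, on a double-bonded ring carbon: 3,4-dimethylphenyl in place of 3,4-difluorophenyl on a double-bonded ring carbon. For the measured compounds named here, only one measured step concerns that place, the modest 3.5-fold lower number from compound 1 to compound 2 (0.54 log units; beyond the scatter), in which 3,4-difluorophenyl replaced 3-bromo-4-methoxyphenyl. Going by the values given here, no measured compound carries 3,4-dimethylphenyl, so that step gives only a rough guide. A small move to a higher number is expected, a 1.5-fold higher number from compound 2 to compound 3 (0.18 log units; within the scatter). For compound 3 the estimated value is 300 nM, with an expected range from 90 nM to 900 nM.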

Compound 3, concentration for 50% growth inhibition: 300 nM
Beside the measured number, compound 3's estimate shows no gap at the digits printed; the range from low to high includes it.
By their numbers in this assay, from the lowest: compounds 2 and 3 (each within the scatter of the next); then compound 1.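

Replacing the two fluorines of 3,4-difluorophenyl with two methyl groups gives a 1.5-fold higher number from compound 2 to compound 3 (0.18 log units; within the scatter) and so makes no clear difference at this position. Measured against 3-bromo-4-methoxyphenyl, the 3,4-dimethylphenyl group gives a 2.3-fold lower number from compound 1 to compound 3 (0.37 log units; beyond the scatter), so both 3,4-disubstituted groups give lower numbers than the bromo-methoxy group on this ring carbon. Nothing available here explains why these groups behave as they do. From the compounds shown here alone, it remains open how this read-out would respond to a phenyl ring carrying an amine or a carboxylic acid at this position.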